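The source may hold more compounds than are shown below. What is called first, only, known or untested is meant among the compounds shown, and "the series" means these compounds.

The series shares a core bearing two 4-fluorophenyl groups on one ring atom and varies the group on a carbon with a double bond to nitrogen. Compound 2 `O=[N+]([O-])c1cccc(C2=NC(c3ccc(F)cc3)(c3ccc(F)cc3)CN2)c1` carries a 3-nitrophenyl there; in an assay on LM cells for displacement of a labelled ligand from Neuropeptide Y receptor type 5 (Homo sapiens) (on this read-out lower numbers stand for stronger inhibition and higher numbers for weaker inhibition), compound 2 gives 4.3 nM, the lowest number of the three measured. Compound 3 `O=Cc1cccc(C2=NC(c3ccc(F)cc3)(c3ccc(F)cc3)CN2)c1` gives 8.7 nM, and the change a 2.0-fold higher number from compound 2 to compound 3 (0.31 log units; beyond the scatter). Among the compounds with values here, compound 1 `Fc1ccc(C2(c3ccc(F)cc3)CNC(c3ccc(C(F)(F)F)cc3)=N2)cc1` gives 160 nM, a far higher number than compound 2, though no one-place step connects them. Compound 4 `Fc1ccc(C2(c3ccc(F)cc3)CNC(c3cccs3)=N2)cc1` differs from compound 2 in one place: thiophen-2-yl in place of 3-nitrophenyl on a carbon with a double bond to nitrogen. Within the data shown here, the only measured step at this place, from compound 2 to compound 3, was modest and toward a higher number; compound 1 shows that another group here can give a much higher number. A loss is therefore expected for compound 4, larger than the step from compound 2 to compound 3 but short of the distance to compound 1. The step expected for compound 4 is a 9.3-fold higher number from compound 2 to compound 4 (0.97 log units; beyond the scatter). Compound 4 is estimated at 40 nM, within 10 nM to 160 nM.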

Compound 4, half-maximal inhibitory concentration: 54 nM
For compound 4 the middle estimate is 1.4-fold (0.13 log units) below the measured one, and the stated range covers the measured number.
By their numbers in this assay, from the lowest: compound 2; then compound 3; then compound 4; then compound 1.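

In this assay, thiophen-2-yl at the carbon with a double bond to nitrogen gives a 13-fold higher number from compound 2 to compound 4 (1.10 log units; beyond the scatter), and a 6.2-fold higher number from compound 3 to compound 4 (0.79 log units; beyond the scatter), so this position responds far more to exchanging the whole aromatic group than the earlier change of a substituent on the phenyl ring suggested. The five-membered ring with its sulfur atom is still accepted to a degree. Keeping a six-membered aromatic ring does not by itself secure a low number: compound 4 differs from compound 1 only at this place, and compound 1 gives 160 nM, while compound 4 gives 54 nM.

Nothing available explains the size of these steps. Ring size, the sulfur atom and the loss of the nitro group remain unseparated, and an unsubstituted phenyl, a furan ring or an amine on the phenyl ring would help to tell them apart.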